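The compounds below may be only part of what the source reports. "The series", "measured", "known", "first", "only" and "open" are said of these compounds alone.

Values in a functional assay on RAW264.7 cells (Mus musculus) for inhibition, read by Griess assay, with stated times of 2 h and 24 h; a lower number here means a stronger inhibitor, a higher number a weaker inhibitor:
compound 1 `COc1ccc([C@@H]2CC(=O)c3c(O)cc(OCc4cn(Cc5ccccc5F)nn4)cc3O2)cc1O`: 7320 nM
compound 2 `C=CCn1cc(COc2cc(O)c3c(c2)O[C@H](c2ccc(OC)c(O)c2)CC3=O)nn1`: 13800 nM
compound 3 `COc1ccc([C@@H]2CC(=O)c3c(O)cc(OCc4cn(Cc5ccccc5Cl)nn4)cc3O2)cc1O`: 6140 nM

Compound 3 gives the lowest of the three numbers in this assay. Its nearest companion is compound 1, with a 1.2-fold lower number from compound 1 to compound 3 (0.08 log units; within the scatter). The gap to compound 2 is larger, with a 2.2-fold lower number from compound 2 to compound 3 (0.35 log units; beyond the scatter), and a 1.9-fold higher number from compound 1 to compound 2 (0.28 log units; within the scatter).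

Compound 4 `COc1ccc([C@@H]2CC(=O)c3c(O)cc(OCc4cn(Cc5cccc(C)c5)nn4)cc3O2)cc1O` differs from compound 3 at one site: 3-methylphenyl in place of 2-chlorophenyl on a saturated chain carbon bound to an aromatic nitrogen. Going by the values given here, no measured step covers a methyl on the aromatic ring of this group. The step that swapped one halogen for another, a 1.2-fold lower number from compound 1 to compound 3 (0.08 log units; within the scatter), stayed within the scatter, and the step that put the whole 2-chlorophenyl group in place of vinyl, a 2.2-fold lower number from compound 2 to compound 3 (0.35 log units; beyond the scatter), was only modest. An aryl group stays in place here, so the expected step in this assay is small: a 1.1-fold higher number from compound 3 to compound 4 (0.02 log units; within the scatter), expected to remain within the scatter. Compound 4 is estimated at 6500 nM in this assay, with an expected range from 3000 nM to 14000 nM.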

Compound 4, half-maximal inhibitory concentration: 17400 nM
Compound 4: middle estimate off by 2.7-fold (0.43 log units), on the low side; the measured number lies above the stated range.
By their numbers in this assay, from the lowest: compounds 3, 1, 2 and 4 (each within the scatter of the next, the first and the last beyond it).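

In this assay an aryl group on this saturated chain carbon does not by itself hold the number: 3-methylphenyl in place of 2-chlorophenyl gives a 2.8-fold higher number from compound 3 to compound 4 (0.45 log units; beyond the scatter) and in place of 2-fluorophenyl gives a 2.4-fold higher number from compound 1 to compound 4 (0.38 log units; beyond the scatter) for this series. Compound 4 also goes against any reading that aryl groups here give lower numbers than vinyl, with a 1.3-fold higher number from compound 2 to compound 4 (0.10 log units; within the scatter) as the step from the vinyl compound. No evidence at hand bears on the origin of these steps.

The compounds shown do not separate the change from chloro or fluoro to methyl from the change in where the ring carries its substituent. On these data alone, how a methoxy group, an amine or a carboxylic acid on this phenyl ring would read also remains open.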